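This account rests on a few compounds, and the source may have more. Where it says the series, first, only, none or still open, it means among the compounds named here.

Compound 1 `O=C(COc1ccc2c(=O)cc(-c3ccccc3)oc2c1)Nc1ccc2ccccc2c1` gives > 10000 nM.
Compound 2 `O=C(COc1ccc2c(=O)c(-c3ccccc3)coc2c1)Nc1ccc2ccccc2c1` gives 1370 nM.
Compound 3 `O=C(COc1ccc2oc(-c3ccccc3)cc(=O)c2c1)Nc1ccc(-c2ccccc2)cc1` gives 640 nM.

All three were tested in a functional assay on NPC-TW01 cells (Homo sapiens) for antiproliferative activity, read by MTT assay, with a stated time of 72 h; on this read-out lower numbers stand for stronger inhibition of growth and higher numbers for weaker inhibition of growth. Compound 1 stands apart from the others: in this assay compound 1 gives > 10000 nM, and that value is a limit of the assay, not a measured number. It belongs to the limit of > 10000 nM in this assay, at which 1 of the 3 values shown sits, so no exact growth inhibition is known for compound 1; it is only known to be weak. Compound 2 and compound 3, by contrast, have numbers, and both show measurable inhibition of growth, with neither compound being compared here by a measured step to compound 1.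

Compound 4 `O=C(COc1ccc2c(=O)cc(-c3ccccc3)oc2c1)Nc1ccccc1` has not yet been tested. It differs from compound 1 in one place: phenyl in place of naphthalen-2-yl on an amide-type nitrogen. Among the compounds with values here, no measured pair of compounds shows what this change does to growth inhibition, so the expected size of the step from compound 1 to compound 4 rests only on the weakness of compound 1 itself. Compound 4 is estimated to remain weak, with the step of a number no higher from compound 1 to compound 4 (the limit leaves the size open) expected to stay within the scatter or to fall again at the limit. The estimate for compound 4 in this assay is 10000 nM, within a range from 3000 nM to 30000 nM.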

Compound 4, concentration for 50% growth inhibition: > 10000 nM
Compound 4: no number, only a limit; the forecaster's own chance of this, stated with the estimate: 60%; the middle value lies on the limit itself.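

Compound 1 and compound 4 each stand at a limit of the assay, not at a measured number, so no step can be read between them: the limit of > 10000 nM in this assay, at which 2 of the 4 values shown sit.

The compounds shown leave open whether phenyl in place of naphthalen-2-yl on an amide-type nitrogen changes growth inhibition at all, and by how much.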